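The source may hold more compounds than are shown below. What is called first, only, known or untested is meant among the compounds shown, and "the series" means these compounds.

Compound 2 `CNC(=O)N1CCCc2ccc(NC(=O)c3ccc(-c4cnn(C)c4)cc3)cc21` gives 77.4% in a functional assay on MV4-11 cells (Homo sapiens) for antiproliferative activity, with a stated time of 6 days, tested at 1.56 uM (on this read-out higher numbers stand for a stronger effect at the one concentration tested and lower numbers for a weaker effect), the highest of the three numbers shown. Compound 1 `CNC(=O)N1CCCc2ccc(NC(=O)c3cccc(-c4cnn(C)c4)c3)cc21` gives 71.2% in this assay, a value that lies within the usual scatter of compound 2, while compound 3 `CNC(=O)N1CCCc2ccc(NC(=O)c3cccc(-c4cnn(C(C)=O)c4)c3)cc21` gives 33.6%.

Compound 4 `CNC(=O)N1CCCc2ccc(NC(=O)c3ccc(-c4cnn(C(C)=O)c4)cc3)cc21` differs from compound 2 in one place: acetyl in place of methyl on an aromatic nitrogen. One measured step shows this same change, and it was large: a number 37.6 percentage points lower from compound 1 to compound 3 (beyond the scatter). The same change is therefore expected to lower the number by a similar amount, which means an expected step of a number 37.4 percentage points lower from compound 2 to compound 4 (beyond the scatter) in this assay.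

On that basis compound 4 is estimated to give about 40% in this assay, with a likely range from 25% to 55%.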

Compound 4, a percentage reported as inhibition, at one concentration (the size of the read-out at that concentration, not a potency): 23.9%
Beside the measured number, compound 4's estimate is 16.1 percentage points above it, and the stated range ends above it.
By their numbers in this assay, from the lowest: compounds 4 and 3 (each within the scatter of the next); then compounds 1 and 2 (each within the scatter of the next).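

In this assay, acetyl in place of methyl on the aromatic nitrogen again lowers the number, with a number 53.5 percentage points lower from compound 2 to compound 4 (beyond the scatter), so the loss is now seen on two cores rather than one. The change does not cost the same amount on each core, so its size depends on the rest of the molecule: the same change on two cores in this assay, a number 37.6 percentage points lower (beyond the scatter) from compound 1 to compound 3 and a number 53.5 percentage points lower (beyond the scatter) from compound 2 to compound 4, 15.9 percentage points apart, beyond the scatter of two such steps

On these data alone, what remains open is whether the loss follows from the carbonyl or simply from the extra atoms of the acetyl. An ethyl or propyl chain on this nitrogen, which has no carbonyl, would separate the two.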